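The compounds below may be only part of what the source reports. "The series", "measured", "known", "first", "only" and "open" are said of these compounds alone.

Among the compounds with values here, in a functional assay on MCF7 cells (Homo sapiens) for antiproliferative activity, read by sulforhodamine B assay, with a stated time of 48 h (on this read-out lower numbers stand for stronger inhibition and higher numbers for weaker inhibition), compound 1 (`Cc1ccc(NS(=O)(=O)c2ccc(N3CCNC3=O)cc2)cc1`) gives 610 nM and compound 2 (`O=C1NCCN1c1ccc(S(=O)(=O)Nc2ccccc2)cc1`) gives 470 nM, which places compound 2 within the scatter of the only other measured number. Compound 3 (`O=C1NCCN1c1ccc(S(=O)(=O)Nc2ccc(F)c(F)c2)cc1`) has 3,4-difluorophenyl in place of phenyl on a sulfonamide nitrogen. Within the data shown here, the one measured step on that aromatic group, a 1.3-fold lower number from compound 1 to compound 2 (0.11 log units; within the scatter), replaces methyl with hydrogen on an aromatic carbon and stays within the scatter. No fluorine change has been measured, so only a small shift is expected in this assay, with no firm direction. The expected step is a 1.2-fold lower number from compound 2 to compound 3 (0.07 log units; within the scatter). Compound 3 is estimated at 400 nM, with an expected range of 130 nM to 1200 nM.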

Compound 3, half-maximal inhibitory concentration: 620 nM
Compound 3: middle estimate off by 1.6-fold (0.19 log units), on the low side; measured number inside the range.
By their numbers in this assay, from the lowest: compounds 2, 1 and 3 (each within the scatter of the next).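

In this assay the change to 3,4-difluorophenyl on a sulfonamide nitrogen brings a 1.3-fold higher number from compound 2 to compound 3 (0.12 log units; within the scatter) and, set against 4-methylphenyl, a 1.0-fold higher number from compound 1 to compound 3 (0.01 log units; within the scatter) so neither step leaves the scatter. Within the data shown here, this is the first fluorine change seen here, and it shows that this place accepts two fluorine atoms with no readable change in the number. Phenyl, 4-methylphenyl and 3,4-difluorophenyl now all lie within the scatter of one another.

From the compounds shown here alone, whether an amine or a carboxylic acid on this aromatic group would move the number beyond the scatter stays open. No measurement at hand speaks to why these numbers lie so close.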